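The source may report more compounds than this note shows. Statements on the series, on what has been measured and on what is new or still open speak of the compounds shown alone.

Working notes on the series. Going by the values given here, compound 2 `COc1cc(Cl)cc(-c2nn(-c3cccc(NC(=O)Nc4cccc(C(F)(F)F)c4)c3)cc2-c2ccncc2)c1` stands at the higher of the two numbers so far in a functional assay on SW-620 cells (Homo sapiens) for inhibition, read by sulforhodamine B assay, with a stated time of 48 h, tested at 0.01 uM (on this read-out higher numbers stand for a weaker effect at the one concentration tested and lower numbers for a stronger effect), where compound 2 gives 103%; its nearest neighbour is compound 1 `COc1cc(Cl)cc(-c2nn(-c3cccc(NC(=O)Nc4ccc(Cl)c(Cl)c4)c3)cc2-c2ccncc2)c1`, and in this assay compound 1 gives 100%. The one measured step, a number 3 percentage points higher from compound 1 to compound 2 (within the scatter), lies within the scatter, so on the numbers shown the two compounds cannot be ordered.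

Compound 3 `COc1cc(Cl)cc(-c2nn(-c3cccc(NC(=O)c4cccc(C(F)(F)F)c4)c3)cc2-c2ccncc2)c1` differs from compound 2 by 3-(trifluoromethyl)phenyl in place of (3-(trifluoromethyl)phenyl)amino on a carbonyl carbon. Among the compounds with values here, no measured step touches a change at the carbonyl carbon; the only step known, a number 3 percentage points higher from compound 1 to compound 2 (within the scatter), concerns the aromatic group on the amide-type nitrogen and is within the scatter. With both measured numbers near the top of the read-out, no step beyond the scatter is expected in this assay for this change.

For compound 3 the estimated value in this assay is 100%, with an expected range from 85% to 115%, which means an expected step of a number 3 percentage points lower from compound 2 to compound 3 (within the scatter).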

Compound 3, a percentage reported as activity, at one concentration (the size of the read-out at that concentration, not a potency): 101%
Compound 3: the middle estimate sits 1 percentage points below what was measured, within the range that was stated.
By their numbers in this assay, from the lowest: compounds 1, 3 and 2 (each within the scatter of the next).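

Going by these compounds alone, the first change at the carbonyl carbon, 3-(trifluoromethyl)phenyl in place of (3-(trifluoromethyl)phenyl)amino, gives a number 2 percentage points lower from compound 2 to compound 3 (within the scatter) in this assay, so removing the amino nitrogen and its hydrogen-bond donor leaves no readable difference at this one concentration. The same position, read against the 3,4-dichlorophenyl compound, gives a number 1 percentage points higher from compound 1 to compound 3 (within the scatter), so the three compounds cannot be ordered on these numbers. Nothing on hand offers an account of this result.

As far as these compounds go, all three compounds carry an aromatic group at this position, so whether an aliphatic amine or a longer alkyl chain on the carbonyl carbon would shift the read-out stays open. Also open, from the compounds shown here alone, is whether compound 2 and compound 3 would separate at a higher concentration, or whether a carboxylic acid in place of trifluoromethyl would change the picture.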